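From pyridin-4-yl to 2-chloropyridin-4-yl at compound 3

The compounds below may be only part of what the source reports. "The series", "measured", "known", "first", "only" and "open" are said of these compounds alone.

Compound 3 `Cc1cccc(-c2nn3c(c2-c2ccncc2)C(C)C(C)(C)C3)n1` offers no number to start from. In a functional assay on MCF7 cells (Homo sapiens) for cytotoxicity, with a stated time of 72 h (on this read-out lower numbers stand for stronger inhibition and higher numbers for weaker inhibition), compound 3 gives > 100000 nM, which is a limit of the assay. Compound 1 `Cc1cc(-c2c(-c3cccc(C)n3)nn3c2C(C)C(C)(C)C3)ccn1` gives > 100000 nM, also a limit. Compound 2 `Cc1cccc(-c2nn3c(c2-c2ccnc(Cl)c2)CC(C)(C)C3)n1` gives > 100000 nM, again a limit. For the measured compounds named here, the series so far therefore reads as the limit of > 100000 nM in this assay, at which 3 of the 3 values shown sit.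

Compound 4 `Cc1cccc(-c2nn3c(c2-c2ccnc(Cl)c2)C(C)C(C)(C)C3)n1` is made from compound 3 by putting chloro in place of hydrogen on an aromatic carbon, next to the ring nitrogen, so that pyridin-4-yl becomes 2-chloropyridin-4-yl: chloro in place of hydrogen on an aromatic carbon.

Going by the values given here, the only measured step close to this change, also at an aromatic carbon, is a step that the two limits leave unreadable from compound 1 to compound 3, and it supplies no size to carry over. Compound 2 carries the same 2-chloropyridin-4-yl group and still shows only the limit of > 100000 nM, so nothing measured points to a gain in this assay. The expected result is a number no higher from compound 3 to compound 4 (the limit leaves the size open), which means no expected change beyond the scatter. The estimate for compound 4 is 100000 nM, with an expected range of 40000 nM to 200000 nM, and the assay will most probably report a limit again.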

Compound 4, half-maximal inhibitory concentration: > 100000 nM
Compound 4: only a limit was reported (the forecaster's own chance of this, stated with the estimate: 85%); the middle value lies on the limit itself.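

No step can be read for compound 4: its comparisons with compound 1, compound 2 and compound 3 in this assay each join two limits, so none has a size: the limit of > 100000 nM in this assay, at which 4 of the 4 values shown sit.

The compounds shown leave open whether chloro, methyl or hydrogen at these places makes any difference to the read-out in this assay, as none of the four has a number.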